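A few compounds are considered here, and "the series" means these few. Any claim that something is new, unique, unknown or untested is made for them only; others in the source may bear on it.

Among the compounds with values here, compound 2 `O=C1COC(c2ccc(/N=C/c3cccc(Cl)c3)cc2)=NN1` gives 257 nM in an assay on cells for inhibition of Amine oxidase [flavin-containing] B (Homo sapiens), read by Amplex Red, with a stated time of 30 min (on this read-out higher numbers stand for weaker inhibition and lower numbers for stronger inhibition), and sits at the lower end of the two numbers so far, with compound 1 `O=C1COC(c2ccc(/N=N/c3cccc(Cl)c3)cc2)=NN1` at 287 nM in this assay, a gap within the scatter. Compound 3 `O=C1COC(c2ccc(/N=C/c3ccc(Cl)cc3)cc2)=NN1` differs from compound 2 by 4-chlorophenyl in place of 3-chlorophenyl on a carbon with a double bond to nitrogen. Within the data shown here, no step of this kind has been measured, so the expectation is a step of a 1.0-fold higher number from compound 2 to compound 3 (0.01 log units; within the scatter), nothing beyond the scatter. Compound 3 is estimated at 260 nM in this assay, between 110 nM and 620 nM.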

Compound 3, half-maximal inhibitory concentration: 433 nM
For compound 3 the middle estimate is 1.7-fold (0.22 log units) below the measured one; measured number inside the range.
By their numbers in this assay, from the lowest: compounds 2, 1 and 3 (each within the scatter of the next).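

Swapping 3-chlorophenyl for 4-chlorophenyl on a carbon with a double bond to nitrogen gives a 1.7-fold higher number from compound 2 to compound 3 (0.23 log units; within the scatter) in this assay, so this change in chlorine placement stays within the scatter. Within the data shown here, compounds 1 and 2 both carry 3-chlorophenyl, so this is the first reading of any change at this position. No measurement available here bears on this step.

Still open, on these data alone, is whether an amine or a carboxylic acid on this phenyl ring, in place of chlorine, would move the number beyond the scatter. Also open, as far as these compounds go, is how the unsubstituted phenyl group would read.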